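Benzylic headgroup swaps on a thiophene sulfonylcarbamate series

This account rests on a few compounds, and the source may have more. Where it says the series, first, only, none or still open, it means among the compounds named here.

Three measured compounds share one core and differ only in the group carried on a saturated chain carbon bound to an aromatic carbon. Compound 1 `CCCCOC(=O)NS(=O)(=O)c1sc(CC(C)C)cc1-c1ccc(Cn2cccn2)cc1` gives 2.3 nM in an assay on membranes from uterus for displacement of a labelled ligand from Angiotensin type II receptor (Sus scrofa), with a stated time of 1.5 h; on this read-out lower numbers stand for stronger inhibition and higher numbers for weaker inhibition. Compound 2 `CCCCOC(=O)NS(=O)(=O)c1sc(CC(C)C)cc1-c1ccc(Cc2ncco2)cc1` gives 3.9 nM in this assay, and compound 3 `CCCCOC(=O)NS(=O)(=O)c1sc(CC(C)C)cc1-c1ccc(CN2CCCC2=O)cc1` gives 3.5 nM in this assay. Compound 3 stands second highest of the three numbers: its nearest neighbour is compound 2, a 1.1-fold lower number from compound 2 to compound 3 (0.05 log units; within the scatter), and its furthest is compound 1, a 1.5-fold higher number from compound 1 to compound 3 (0.18 log units; within the scatter). The remaining pair, a 1.7-fold higher number from compound 1 to compound 2 (0.23 log units; within the scatter), completes the picture: every exchange of the headgroup so far has stayed within the scatter.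

Compound 4 `CCCCOC(=O)NS(=O)(=O)c1sc(CC(C)C)cc1-c1ccc(Cn2cnc(C(F)(F)F)c2)cc1` continues this pattern of headgroup exchange, with 4-(trifluoromethyl)-1H-imidazol-1-yl in place of 2-oxopyrrolidin-1-yl on a saturated chain carbon bound to an aromatic carbon. Among the compounds with values here, the steps that bear on it are those from compound 1 to compound 3 and from compound 2 to compound 3, both within the scatter, and the step from compound 1 to compound 2 adds a third headgroup swap of the same kind and the same small size. No basis exists here for a step beyond the scatter in this assay in either direction.

Compound 4 is therefore expected to give about 3.2 nM in this assay, with a range from 1.2 nM to 9 nM. For compound 4 the estimated step is a 1.1-fold lower number from compound 3 to compound 4 (0.04 log units; within the scatter).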

Compound 4, inhibition constant: 7.3 nM
Compound 4: middle estimate off by 2.3-fold (0.36 log units), on the low side; measured number inside the range.
By their numbers in this assay, from the lowest: compounds 1, 3, 2 and 4 (each within the scatter of the next, the first and the last beyond it).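

Within the data shown here, this position is not indifferent to the headgroup in this assay: 4-(trifluoromethyl)-1H-imidazol-1-yl in place of 2-oxopyrrolidin-1-yl gives a 2.1-fold higher number from compound 3 to compound 4 (0.32 log units; beyond the scatter), and the same group in place of 1H-pyrazol-1-yl gives a 3.2-fold higher number from compound 1 to compound 4 (0.50 log units; beyond the scatter), both modest and both beyond the scatter, whereas every exchange among the earlier compounds stayed within it. The exchange for 1,3-oxazol-2-yl, a 1.9-fold higher number from compound 2 to compound 4 (0.27 log units; within the scatter), remains within the scatter, so compound 4 separates from compound 1 and compound 3 but not from compound 2. Nothing available accounts for these steps.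

A plain 1H-imidazol-1-yl headgroup, or one carrying methyl in place of trifluoromethyl, would separate the contribution of the trifluoromethyl from that of the ring, and the compounds shown leave this question open. Equally open, as far as these compounds go, is whether a carboxylic acid or an amine on the saturated chain carbon bound to an aromatic carbon would give a larger step than any headgroup seen here.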